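This account rests on a few compounds, and the source may have more. Where it says the series, first, only, none or still open, it means among the compounds named here.

- compound 1 `O=C(CSc1ncnn1-c1ccc(Cl)cc1Cl)Nc1ccccc1F` gives 38400 nM
- compound 2 `Cc1ccccc1NC(=O)CSc1ncnn1-c1ccc(Cl)cc1Cl` gives 106000 nM
- compound 3 `CC(=O)c1ccc(NC(=O)CSc2ncnn2-c2ccc(Cl)cc2Cl)c(Br)c1` gives 114000 nM

In an ADME assay on MT4 cells (Homo sapiens) for cytotoxicity, read by MTT assay, with a stated time of 5 days (on this read-out higher numbers stand for lower toxicity in this test and lower numbers for higher toxicity in this test), compound 3 gives 114000 nM as its value, level within the scatter with compound 2 and clearly above compound 1. The unmeasured compound 4 `CCOC(=O)c1ccc(NC(=O)CSc2ncnn2-c2ccc(Cl)cc2Cl)c(Br)c1` differs from compound 3 by ethoxy in place of methyl on a carbonyl carbon. For the measured compounds named here, the only measured step of a 2.8-fold higher number from compound 1 to compound 2 (0.44 log units; beyond the scatter) is modest and concerns methyl in place of fluoro on an aromatic carbon, so it is only a loose guide. Going by the values given here, no measured step touches this carbonyl carbon, so no change beyond the scatter is expected in this assay here. The estimated step is a 1.3-fold lower number from compound 3 to compound 4 (0.10 log units; within the scatter) in size. For compound 4 the estimated value is 90000 nM (expected range 40000 nM to 200000 nM).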

Compound 4, half-maximal cytotoxic concentration: 33100 nM
The estimate for compound 4 lay 2.7-fold (0.43 log units) above the measured number; the measured number lies below the stated range.
By their numbers in this assay, from the lowest: compounds 4 and 1 (each within the scatter of the next); then compounds 2 and 3 (each within the scatter of the next).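

In this assay, the carbonyl carbon turns out to be a sensitive place: acetyl to ethoxycarbonyl gives a 3.4-fold lower number from compound 3 to compound 4 (0.54 log units; beyond the scatter) and so means higher toxicity in this test. For the compounds shown here, the earlier step concerned an aromatic carbon and went the other way, so this is the first sign that a change on the carbonyl carbon can move the number beyond the scatter. Nothing measured here explains the drop.

Still open, as far as these compounds go, is whether the added oxygen or the longer chain matters more. Methoxy, propyl or a carboxylic acid on this carbonyl carbon would help separate these.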